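The compounds below may be only part of what the source reports. "The series", "measured", "known", "first", "only" and "open" are said of these compounds alone.

Measured so far:
compound 1, `COc1ccc(/C(C)=C(/C)C(=O)NC2CC2)cc1`, 300 mg/kg;
compound 2, `C=CCNC(=O)/C(C)=C(/C)c1ccc(C)cc1`, 400 mg/kg;
compound 3, `C=CCNC(=O)/C(C)=C(\C)c1ccc(C)cc1`, 150 mg/kg.

All three numbers come from a toxicity assay on the whole organism (strain Icem-CET (SPF Caw)) for cytotoxicity, with Mus musculus as the target; a lower number here means that less compound is needed, a higher number that more compound is needed for the effect. Compound 2 stands at the high end of the three: compound 1 sits close to it, within the scatter, and only compound 3 lies clearly apart, as the step of a 2.7-fold lower number from compound 2 to compound 3 (0.43 log units; beyond the scatter) shows. That step rests on the fact that compounds 2 and 3 differ only in the configuration as drawn and says nothing about substituents on the ring.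

Compound 4, `C=CCNC(=O)/C(C)=C(/C)c1ccc(OC)cc1`, is to be measured in this assay. It comes from compound 2 by the change (methoxy in place of methyl on an aromatic carbon). Going by the values given here, no measured step carries exactly this change. What bears on it is the pair of values from compound 1 and compound 2: compound 1 already carries the methoxy, and its value sits within the scatter of compound 2. On that basis the expected step of a 1.3-fold lower number from compound 2 to compound 4 (0.12 log units; within the scatter) is small, with no direction beyond the scatter. Compound 4 is therefore expected to give about 300 mg/kg, with a range from 150 mg/kg to 600 mg/kg.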

Compound 4, dose for half-maximal effect: 400 mg/kg
The estimate for compound 4 lay 1.3-fold (0.12 log units) below the measured number; the measured number falls inside the stated range.
By their numbers in this assay, from the lowest: compounds 3, 1, 2 and 4 (each within the scatter of the next, the first and the last beyond it).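

In this assay, methoxy in place of methyl on an aromatic carbon, para to a large group, can now be read on its own, without a second difference elsewhere in the molecule, and it gives no change at the digits printed from compound 2 to compound 4 (within the scatter). With the methoxy held in place, allyl in place of cyclopropyl on an amide-type nitrogen gives a 1.3-fold higher number from compound 1 to compound 4 (0.12 log units; within the scatter), so neither single change moves the number beyond the scatter in these compounds. Nothing known about these compounds speaks to why the number responds so little to either change.

Going by these compounds, whether an amine, a hydroxyl or a chlorine at this ring position would behave like methyl and methoxy remains open, as does the effect of a longer chain on the amide nitrogen. On these data alone, it is also open whether the configuration step, a 2.7-fold lower number from compound 2 to compound 3 (0.43 log units; beyond the scatter), carries over to compounds with the methoxy on the ring.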